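Replacing an arylamino hydrazide by a diacylhydrazine

The source may hold more compounds than are shown below. What is called first, only, known or untested is meant among the compounds shown, and "the series" means these compounds.

Measured so far:
compound 1 `O=C(NNc1cccc(Cl)c1)c1ccc(NS(=O)(=O)c2cnc(O)nc2O)cc1` 17400 nM
compound 2 `O=C(NNc1cccc(Cl)c1)c1ccccc1NS(=O)(=O)c1cnc(O)nc1O` 11800 nM

Of the compounds shown here, two have been tested in a functional assay on MDA-MB-231 cells (Homo sapiens) for antiproliferative activity, read by MTT assay, with a stated time of 24 h; on this read-out higher numbers stand for weaker inhibition and lower numbers for stronger inhibition. Compound 1 gives 17400 nM, and compound 2 gives 11800 nM. Compound 2 has the lowest number of the two, but the gap to compound 1 lies within the usual scatter of this assay, so the two cannot be told apart on these numbers.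

Compound 3 `O=C(NNC(=O)c1ccccc1NS(=O)(=O)c1cnc(O)nc1O)c1ccc(F)cc1` has not yet been measured in this assay. It differs from compound 2 in one place: (4-fluorophenyl)carbonyl in place of 3-chlorophenyl on an amine nitrogen. For the measured compounds named here, no step between two measured compounds touches this part of the molecule, so there is nothing in the data to say how such a change shifts the read-out.

With both measured compounds sitting close together in the weak range, compound 3 is expected to stay near them; the step of a 1.1-fold lower number from compound 2 to compound 3 (0.03 log units; within the scatter) is estimated to be no larger than the scatter, in no settled direction. Compound 3 is therefore expected to give 11000 nM in this assay, between 3500 nM and 35000 nM.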

Compound 3, half-maximal inhibitory concentration: > 20000 nM
Compound 3 gave a limit, no number (the forecaster's own chance of this, stated with the estimate: 10%); at least 1.8-fold (0.25 log units) between middle value and limit.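

In this assay compound 3 reads > 20000 nM, which is a limit of the assay and not a number. For the compounds shown here, this gives the first step at this place on the amine nitrogen, with (4-fluorophenyl)carbonyl in place of 3-chlorophenyl, and it reads as an at least 1.6-fold higher number from compound 2 to compound 3 (0.22 log units; that floor lies within the scatter). The change therefore brought no lower number, yet that floor does not separate the two compounds beyond the scatter, and the full size of the step cannot be read; the only further information on this is the ceiling of the read-out itself: the limit of > 20000 nM in this assay, at which 1 of the 3 values shown sits.

The step changes two things at once, the carbonyl that turns the arylamino hydrazide into a diacylhydrazine and the ring substituent, and the compounds shown do not tell these two apart. A (3-chlorophenyl)carbonyl group or a 4-fluorophenyl group on the same nitrogen would separate them, while a benzyl group or a chain ending in a carboxylic acid at this place remains entirely open.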